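From Amino to Aminoamino on a Shared Core

The compounds below may be only part of what the source reports. "The series", "measured", "known", "first", "only" and "open" are said of these compounds alone.

Compound 1 `COc1ccc2c(c1)CCc1ccc(OC)c(c1)Oc1ccc(cc1)-c1nc(N)sc1-c1cccc(c1)O2` stands highest of the two compounds measured in a functional assay on K562 cells (Homo sapiens) for cytotoxicity, read by MTT assay, with a stated time of 48 h, tested at 10 uM; a lower number here means less inhibition, a higher number more inhibition at the concentration tested (going by the name of the read-out): compound 1 gives 58.7%, while compound 2 `Nc1nc2c(s1)-c1cccc(c1)Oc1ccc(O)cc1CCc1ccc(O)c(c1)Oc1ccc-2cc1` gives 11.6%, a gap beyond the usual scatter. Compound 3 `COc1ccc2c(c1)CCc1ccc(OC)c(c1)Oc1ccc(cc1)-c1nc(NN)sc1-c1cccc(c1)O2` differs from compound 1 by a single change, (amino in place of hydrogen on a nitrogen on an aromatic ring). Within the data shown here, no measured pair carries this same change, so no step can be read from the numbers at hand. The expected step is small, within the scatter, and is estimated as a number 3.7 percentage points lower from compound 1 to compound 3 (within the scatter). Compound 3 is expected to give 55%, in a range from 30% to 78%.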

Compound 3, a percentage reported as inhibition, at one concentration (the size of the read-out at that concentration, not a potency): 32.1%
Compound 3: the middle estimate sits 22.9 percentage points above what was measured; measured number inside the range.
By their numbers in this assay, from the lowest: compound 2; then compound 3; then compound 1.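

Among these compounds, the first step that can be read at this position comes from lengthening amino to aminoamino on the shared core: in this assay it is a number 26.6 percentage points lower from compound 1 to compound 3 (beyond the scatter) and shows that this nitrogen on an aromatic ring does not take the added amino without a loss of inhibition. Nothing at hand explains this step. The compounds shown leave open whether a methyl or an acetyl group on this nitrogen would lower the number as well. They also leave open whether the same change would give a similar step on compound 2 .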